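Replacing the fused ring group of compound 2

A few compounds are considered here, and "the series" means these few. Any claim that something is new, unique, unknown or untested is made for them only; others in the source may bear on it.

Measured in an ADME assay (liver) for metabolic stability, with Liver microsome (Homo sapiens) as the target, using microsomes and NADPH, with a stated time of 30 min, tested at 1 uM; a higher number here means faster removal of the compound, a lower number slower removal:
- Compound 1 `Cn1cc(-c2cc(C(O)(C(F)(F)F)C(F)(F)F)cnc2N2CCN(S(=O)(=O)c3ccc(N)nc3)CC2)cn1`: 19 mL.min-1.g-1
- Compound 2 `Nc1ccc(S(=O)(=O)N2CCN(c3ncc(C(O)(C(F)(F)F)C(F)(F)F)cc3-c3ccc4ocnc4c3)CC2)cn1`: < 14 mL.min-1.g-1 (a limit of the assay, not a number)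

Compound 2 stands at the limit of < 14 mL.min-1.g-1 in this assay, at which 1 of the 2 values shown sits. Its position is therefore known only as a limit, and no exact number is available as a starting point for the next step.

The change to compound 3 `Nc1ccc(S(=O)(=O)N2CCN(c3ncc(C(O)(C(F)(F)F)C(F)(F)F)cc3-c3ccc4c(c3)CC(=O)N4)CC2)cn1` is a group of 10 heavy atoms (8 carbon, 1 nitrogen, 1 oxygen; one five-membered non-aromatic ring with 1 hetero atom, one six-membered aromatic ring of carbon only) in place of a group of 9 heavy atoms (7 carbon, 1 nitrogen, 1 oxygen; one five-membered aromatic ring with 2 hetero atoms, one six-membered aromatic ring of carbon only), on an aromatic carbon. It sits on an aromatic carbon of a six-membered aromatic ring with 1 nitrogen, the same place where compound 1 and compound 2 differ.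

Within the data shown here, only one measured step bears on this change: an at least 1.3-fold lower number from compound 1 to compound 2 (0.13 log units; that floor lies within the scatter). That step is also an exchange of one group on an aromatic carbon, but it gives a floor and not a size. It favours no direction for the new group, so no step beyond the scatter is expected in this assay.

The expected step is a number no lower from compound 2 to compound 3 (the limit leaves the size open), an estimate that carries the uncertainty of the limit. For compound 3 the estimated value is 14 mL.min-1.g-1, with an expected range from 8 mL.min-1.g-1 to 28 mL.min-1.g-1.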

Compound 3, intrinsic clearance in microsomes: < 14 mL.min-1.g-1
Compound 3: a limit, no number; the forecaster's own chance of this, stated with the estimate: 55%; the middle value lies on the limit itself.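

In this assay compound 3 gives < 14 mL.min-1.g-1, which is a limit of the assay and not a number. On this aromatic carbon, a fused group with a five-membered non-aromatic ring and one hydrogen-bond donor now ends at the same limit as 1,3-benzoxazol-5-yl, which has an aromatic five-membered ring and no donor, so the step between these two compounds cannot be read: the limit of < 14 mL.min-1.g-1 in this assay, at which 2 of the 3 values shown sit.

The exchange of 1-methyl-1H-pyrazol-4-yl for the new fused group gives an at least 1.3-fold lower number from compound 1 to compound 3 (0.13 log units; that floor lies within the scatter), so this second fused group also yields only a floor and not a size.

As far as these compounds go, how far compound 2 and compound 3 lie beyond the limit remains unknown, and with it any order between their two fused groups. Also open, from the compounds shown here alone, is whether a carboxylic acid or an open-chain amine on the same aromatic carbon would give a readable number in this assay.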